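The source may hold more compounds than are shown below. What is called first, only, known or untested is meant among the compounds shown, and "the series" means these compounds.

Of the compounds shown here, two have been measured in an in vivo ADME assay on the whole organism (Rattus norvegicus, strain Sprague Dawley) for pharmacokinetics (on this read-out lower numbers stand for lower oral bioavailability and higher numbers for higher oral bioavailability), so far. Compound 1 `CNC(=O)c1ccccc1-c1ccc(CNc2ncccc2NC(=O)CC(F)(F)F)cc1` gives 95% in this assay. Compound 2 `CNC(=O)c1ccccc1-c1ccc([C@@H](C)Nc2nccc(C)c2NC(=O)CC(F)(F)F)cc1` gives 25% in this assay, the lower of the two numbers, and the distance between compound 2 and compound 1 lies beyond the scatter of repeated measurements. The two compounds differ in more than one place, so their gap cannot be tied to a single change.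

Compound 3 `COC(=O)c1ccccc1-c1ccc([C@@H](C)Nc2nccc(C)c2NC(=O)CC(F)(F)F)cc1` has not yet been measured. It differs from compound 2 in one place: methoxy in place of methylamino on a carbonyl carbon. Within the data shown here, no pair of measured compounds shows this exchange, so the present numbers fix neither its size nor its direction. The expected step from this exchange is a number 5 percentage points higher from compound 2 to compound 3 (within the scatter), and either direction remains possible. Compound 3 is therefore estimated at 30%, within a range from 8% to 65%.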

Compound 3, oral bioavailability: 17%
Estimate against measurement, compound 3: 13 percentage points above; the measured number falls inside the stated range.
By their numbers in this assay, from the lowest: compounds 3 and 2 (each within the scatter of the next); then compound 1.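

In this assay, among these compounds, methoxy in place of methylamino on a carbonyl carbon gives a number 8 percentage points lower from compound 2 to compound 3 (within the scatter), the first step that can be tied to a single change. At this place, the exchange takes away the hydrogen-bond donor of methylamino and brings in the hydrogen-bond acceptor of methoxy, yet the two compounds cannot be told apart on this read-out. Nothing measured here speaks to what lies behind this result.

The compounds shown leave open how a carboxylic acid, or an amide with a longer chain such as ethylamino, would read on this same carbonyl carbon. Also open, going by these compounds, is whether this exchange would give a step of similar size on the core of compound 1.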